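The source may hold more compounds than are shown below. What is called first, only, known or untested is meant among the compounds shown, and "the series" means these compounds.

Among the compounds with values here, compound 1, `N=C(NCCCc1c[nH]cn1)NCCCC(c1ccccc1)c1ccccn1`, is one of three compounds measured in a functional assay on ileum for antagonist activity at histamine H1 receptor (Cavia porcellus); a lower number here means a less potent compound, a higher number a more potent compound, by a factor of ten per unit of this negative logarithm. Compound 1 gives 6.06, the highest of the three numbers. Compound 2, `CN/C(=N\CCC(c1ccc(Br)cc1)c1ccccn1)NCCCc1c[nH]cn1`, gives 5.71 in this assay, a number that lies beyond the scatter below compound 1. Compound 3, `Brc1ccc(C(CC/N=C(/NCCCc2c[nH]cn2)NC2CCCCC2)c2ccccn2)cc1`, gives 5.42 in this assay, the furthest from compound 1 and also beyond the scatter. Compound 2 and compound 3 differ from each other in one place only, a group on an amine nitrogen. That one measured single step, a number 0.29 log units lower from compound 2 to compound 3 (within the scatter), stays within the scatter. Both compound 2 and compound 3 differ from compound 1 in more than one place, so their numbers say nothing direct about any single change.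

Compound 4, `N=C(NCCCc1c[nH]cn1)NCCCC(c1ccc(Cl)c(Cl)c1)c1ccccn1`, is not yet measured. It differs from compound 1 in one place: 3,4-dichlorophenyl in place of phenyl on a saturated chain carbon bound to an aromatic carbon and a saturated chain carbon. Within the data shown here, no measured step touches this place; the only measured step concerns an amine nitrogen and was small. With no closer guide, the step from compound 1 to compound 4 is expected to be small, a number 0.16 log units lower from compound 1 to compound 4 (within the scatter), with none beyond the scatter the likeliest outcome. Compound 4 is therefore estimated at 5.9 in this assay, within a range from 5.3 to 6.5.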

Compound 4, negative logarithm of the antagonist equilibrium constant: 7.46
For compound 4 the middle estimate is 1.56 log units below the measured one; measured number above the stated range.
By their numbers in this assay, from the lowest: compounds 3 and 2 (each within the scatter of the next); then compound 1; then compound 4.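

In this assay, 3,4-dichlorophenyl in place of phenyl on a saturated chain carbon bound to an aromatic carbon and a saturated chain carbon gives a number 1.40 log units higher from compound 1 to compound 4 (beyond the scatter), the first single change measured at this position, and it shows that the number responds strongly to what is on this ring. Within the data shown here, the only earlier single step concerned a group on an amine nitrogen and gave a number 0.29 log units lower from compound 2 to compound 3 (within the scatter), so compound 4 offers the first sign of a place in the structure where one change moves the number well beyond the scatter; the change adds two chlorine atoms, while the count of hydrogen-bond donors and acceptors and the net charge stay as they were. Nothing available here speaks to the reason for a step of this size.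

As far as these compounds go, whether one chlorine alone, as in 3-chlorophenyl or 4-chlorophenyl, would give a step of similar size remains open. So does whether other groups at this place, such as 3,4-difluorophenyl or 3,4-dimethylphenyl, would match 3,4-dichlorophenyl.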